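A few compounds are considered here, and "the series" means these few. Any claim that something is new, unique, unknown or untested is made for them only; others in the source may bear on it.

The measured compounds are compound 1 `C[C@H](NC1=NS(=O)(=O)c2cccnc2N1)C1CCCCC1`, compound 2 `C[C@H](NC1=NS(=O)(=O)c2cccnc2N1)c1ccccc1` and compound 3 `O=S1(=O)NC(NCC2CCCCC2)=Nc2ncc(Cl)cc21`. In a functional assay (aorta) with Rattus norvegicus as the target (on this read-out lower numbers stand for an effect already at smaller amounts and higher numbers for an effect only at larger amounts of compound), compound 1 gives 29.2 uM, compound 2 gives 65.2 uM and compound 3 gives 38.2 uM.

Compound 1 and compound 2 differ by phenyl in place of cyclohexyl on a saturated chain carbon bound to an amine nitrogen and a saturated chain carbon, and in this assay this change produced a 2.2-fold higher number from compound 1 to compound 2 (0.35 log units; beyond the scatter). Compound 3 carries a different core; the difference between the two cores is not broken down here. Its value lies within the scatter of both compound 1 and compound 2.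

Compound 4 `O=S1(=O)NC(NCc2ccccc2)=Nc2ncc(Cl)cc21` differs from compound 3 by phenyl in place of cyclohexyl on a saturated chain carbon bound to an amine nitrogen. This is the same kind of change as that from compound 1 to compound 2, though there the place is a saturated chain carbon bound to an amine nitrogen and a saturated chain carbon, while here it is bound to an amine nitrogen alone. Because a 2.2-fold higher number from compound 1 to compound 2 (0.35 log units; beyond the scatter) was modest, compound 4 is expected to show a 2.0-fold higher number from compound 3 to compound 4 (0.29 log units; within the scatter) in this assay. Compound 4 is therefore estimated at 75 uM, with an expected range from 35 uM to 160 uM.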

Compound 4, concentration for half-maximal effect: 43.6 uM
The estimate for compound 4 lay 1.7-fold (0.24 log units) above the measured number, and the stated range covers the measured number.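

In this assay, phenyl in place of cyclohexyl gave a 1.1-fold higher number from compound 3 to compound 4 (0.06 log units; within the scatter), a step that stays within the scatter. Set beside the earlier step on the other core, it cannot be told apart from it: the same change on two cores in this assay, a 2.2-fold higher number (0.35 log units; beyond the scatter) from compound 1 to compound 2 and a 1.1-fold higher number (0.06 log units; within the scatter) from compound 3 to compound 4, 2.0-fold (0.29 log units) apart, within the scatter of two such steps. Among the compounds shown here, this shows no measurable dependence of the change on the core, but it does not show that the change carries over unaltered: only two cores are compared, and the carbon bearing the group is bound to an amine nitrogen and a saturated chain carbon in one pair and to an amine nitrogen alone in the other.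

The compounds shown leave open whether the step holds on further cores. They also leave open how a longer chain or a carboxylic acid in place of cyclohexyl or phenyl would read in this assay.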